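Cytotoxicity Stays at the Assay Limit Across Aryl Swaps

A few compounds are considered here, and "the series" means these few. Any claim that something is new, unique, unknown or untested is made for them only; others in the source may bear on it.

Compound 1: `O=C(c1ccc2c(c1)OCCO2)C1CCN(Cc2coc(-c3ccccc3)n2)CC1` — > 150 ug/mL
Compound 2: `O=C(c1ccc2c(c1)OCCO2)C1CCN(Cc2coc(-c3ccccc3F)n2)CC1` — > 150 ug/mL

In an ADME assay on HEK293 cells (Homo sapiens) for cytotoxicity, read by MTT assay, with a stated time of 36 h (on this read-out higher numbers stand for weaker inhibition and lower numbers for stronger inhibition), compound 1 gives > 150 ug/mL, which is a limit of the assay and not a measured number. Compound 2 gives > 150 ug/mL, again a limit. The step that the two limits leave unreadable from compound 1 to compound 2 therefore has no readable size, and both values share the same position, (the limit of > 150 ug/mL in this assay, at which 2 of the 2 values shown sit).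

Compound 3, `COc1ccc(-c2nc(CN3CCC(C(=O)c4ccc5c(c4)OCCO5)CC3)co2)cc1`, carries the change (4-methoxyphenyl in place of 2-fluorophenyl on an aromatic carbon). For the measured compounds named here, no measured step has a readable size that bears on this change; the only step available, from compound 1 to compound 2, is unreadable between two limits. What can be said is that neither measured compound showed cytotoxicity within the tested range, and the change to compound 3 alters only the aryl group on the shared core while the rest of the molecule stays the same.

On that basis compound 3 is expected to sit at the limit as well, with an estimated value of 150 ug/mL (range 60 ug/mL to 400 ug/mL), meaning an expected step of a number no higher from compound 2 to compound 3 (the limit leaves the size open) that is most likely not readable beyond the scatter.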

Compound 3, half-maximal inhibitory concentration: > 150 ug/mL
Compound 3 was reported as a limit; the forecaster's own chance of this, stated with the estimate: 85%; the middle value sits exactly at the limit.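

In this assay compound 3 gives > 150 ug/mL, which is a limit of the assay and not a measured number. No step among compound 1, compound 2 and compound 3 can therefore be read: the limit of > 150 ug/mL in this assay, at which 3 of the 3 values shown sit.

The compounds shown leave open what concentration would actually harm these cells, and whether the aryl swaps make any difference.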